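The source may report more compounds than this note shows. Statements on the series, on what has been measured and on what is new or still open speak of the compounds shown alone.

Compound 2 `Cc1cc(C)n(C)c(=O)c1CN1CCc2c(Cl)cc(-c3c(C)noc3C)c(Cl)c2C1=O` gives 14 nM in an assay on isolated protein for inhibition of histone-lysine N-methyltransferase EZH2 (Homo sapiens), read by filter binding, with a stated time of 1 h (on this read-out higher numbers stand for weaker inhibition and lower numbers for stronger inhibition), the lower of the two numbers recorded in this assay. Compound 1 `CCc1cc(C)n(C)c(=O)c1CN1CCc2c(Cl)cc(-c3c(C)noc3C)c(Cl)c2C1=O` carries an ethyl group where compound 2 carries a methyl. In this assay compound 1 gives 82 nM, so the step of a 5.9-fold lower number from compound 1 to compound 2 (0.77 log units; beyond the scatter). Compound 3 `Cc1noc(C)c1-c1cc(Cl)c2c(c1Cl)C(=O)N(Cc1c(C(F)(F)F)cc(C)n(C)c1=O)CC2`, which carries a trifluoromethyl group on that same aromatic carbon, gives > 1000 nM in this assay, a limit of the assay rather than a number; (the limit of > 1000 nM in this assay, at which 1 of the 3 values shown sits). Measured against that limit, the steps of an at least 12-fold higher number from compound 1 to compound 3 (1.08 log units; beyond the scatter) and an at least 71-fold higher number from compound 2 to compound 3 (1.85 log units; beyond the scatter).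

Compound 4 `Cc1cc(C)c(CN2CCc3c(Cl)cc(-c4c(C)noc4C)c(Cl)c3C2=O)c(=O)[nH]1` differs from compound 2 in one place: hydrogen in place of methyl on an aromatic nitrogen. None of the three measured steps touches this ring nitrogen; all of them change the group on the aromatic carbon, so none of them bears directly on the new change, and they give no direction for it. With nothing in the measured compounds pointing up or down, the expectation for compound 4 is a step of a 1.2-fold lower number from compound 2 to compound 4 (0.07 log units; within the scatter) in this assay, that is, none beyond the scatter. Compound 4 is therefore estimated at 12 nM in this assay, within a range from 4 nM to 40 nM.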

Compound 4, half-maximal inhibitory concentration: 1 nM
Compound 4: middle estimate off by 12-fold (1.08 log units), on the high side, outside the stated range (below it).
By their numbers in this assay, from the lowest: compound 4; then compound 2; then compound 1. At a limit, above all of these: compound 3.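

The earlier steps shown here all changed the group on the aromatic carbon, so they said nothing about the ring nitrogen. Replacing the methyl on that aromatic nitrogen with hydrogen gives a 14-fold lower number from compound 2 to compound 4 (1.15 log units; beyond the scatter) in this assay, which shows that this position also matters, even though the change removes only one heavy atom and adds none. The measured compounds show what this change does to the number but offer nothing that explains why it does so.

On these data alone, only methyl and hydrogen appear on this nitrogen, so the effect of an ethyl group, a longer chain or a chain ending in a carboxylic acid at the same place remains open. As far as these compounds go, it also remains open whether hydrogen on the nitrogen would lower the number to a similar degree when the aromatic carbon carries ethyl or trifluoromethyl instead of methyl, since this single step was read with methyl on that carbon.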